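The source may hold more compounds than are shown below. What is called first, only, known or untested is meant among the compounds shown, and "the series" means these compounds.

Compound 1 `N#CC1=C(N)Oc2c(N)cc3nc4ccccc4nc3c2C12C(=O)N(Cc1cnnn1-c1cccc(Br)c1)c1ccccc12`: in an ADME assay on HUVEC cells (Homo sapiens) for antiproliferative activity, read by MTT assay, with a stated time of 48 h (on this read-out higher numbers stand for weaker inhibition and lower numbers for stronger inhibition), compound 1 gives > 50000 nM, which is a limit of the assay.
Compound 2 `COc1ccccc1-n1nncc1CN1C(=O)C2(C(C#N)=C(N)Oc3c(N)cc4nc5ccccc5nc4c32)c2ccccc21`: in this assay compound 2 gives > 50000 nM, again a limit.
Compound 3 `N#CC1=C(N)Oc2c(N)cc3nc4ccccc4nc3c2C12C(=O)N(Cc1cnnn1-c1c(F)cccc1F)c1ccccc12`: in this assay compound 3 gives > 50000 nM, also a limit.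

All three share the same core and differ only in the aryl group on an aromatic nitrogen. The steps among them are not readable: a step that the two limits leave unreadable from compound 1 to compound 2, a step that the two limits leave unreadable from compound 1 to compound 3 and a step that the two limits leave unreadable from compound 2 to compound 3 all sit at the limit of > 50000 nM in this assay, at which 3 of the 3 values shown sit, so no direction can be drawn from them. Compound 3 therefore stands where compounds 1 and 2 stand, at the limit and not above it.

Compound 4 `COc1ccc(OC)c(-n2nncc2CN2C(=O)C3(C(C#N)=C(N)Oc4c(N)cc5nc6ccccc6nc5c43)c3ccccc32)c1` is the next member of the set. The change from compound 3 is 2,5-dimethoxyphenyl in place of 2,6-difluorophenyl on an aromatic nitrogen. Every measured step that bears on this kind of exchange of the aryl group is unreadable, and none of the aryl groups tried so far has moved the read-out off the limit. Compound 4 is thus expected to remain at the limit, a step of a number no higher from compound 3 to compound 4 (the limit leaves the size open) being the estimate. On that basis compound 4 is estimated at 50000 nM, within 20000 nM to 200000 nM, in this assay.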

Compound 4, half-maximal inhibitory concentration: > 50000 nM
Compound 4: only a limit was reported; the forecaster's own chance of this, stated with the estimate: 85%; the middle value lies on the limit itself.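

The result for compound 4 is also a limit, so none of the steps between compound 4 and compounds 1, 2 and 3 can be read: the limit of > 50000 nM in this assay, at which 4 of the 4 values shown sit.

The compounds shown leave open how these four rank in this assay, and whether any aryl group on the aromatic nitrogen would give a measurable value.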